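A Diacid Replaces a Diol on the Amide Nitrogen

The source may report more compounds than this note shows. Statements on the series, on what has been measured and on what is new or still open speak of the compounds shown alone.

Compound 1 `CCn1c(C(=O)NCCN)ccc1C(CC)(CC)c1ccc(OCS(=O)(=O)c2ccccc2)c(C)c1` gives 6430 nM in a functional assay on BXPC-3 cells (Homo sapiens) for antiproliferative activity, read by MTT assay, with a stated time of 24 h; on this read-out higher numbers stand for weaker inhibition and lower numbers for stronger inhibition.
Compound 2 `CCn1c(C(=O)N[C@H](C)CO)ccc1C(CC)(CC)c1ccc(OCS(=O)(=O)c2ccccc2)c(C)c1` gives 10000 nM.
Compound 3 `CCn1c(C(=O)N[C@@H](CO)CCO)ccc1C(CC)(CC)c1ccc(OCS(=O)(=O)c2ccccc2)c(C)c1` reaches only > 50000 nM, which is a limit of the assay and not a number.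

Compound 3 thus stands at the weak end of the three, separated from both others by steps beyond the scatter: an at least 7.7-fold higher number from compound 1 to compound 3 (0.89 log units; beyond the scatter) and an at least 5.0-fold higher number from compound 2 to compound 3 (0.69 log units; beyond the scatter). Compound 4 `CCn1c(C(=O)N[C@H](CCC(=O)O)C(=O)O)ccc1C(CC)(CC)c1ccc(OCS(=O)(=O)c2ccccc2)c(C)c1` differs from compound 3 in one place: 1,3-dicarboxypropyl in place of 3-hydroxy-1-(hydroxymethyl)propyl on an amide-type nitrogen. Both measured steps onto this amide-type nitrogen ended at the limit, and none shows a larger group there returning to a numbered value. Compound 4 is therefore expected to stay at or past the limit, with a step that the limit leaves unreadable from compound 3 to compound 4 expected to be nothing beyond the scatter. Compound 4 is estimated at 60000 nM, within 20000 nM to 200000 nM.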

Compound 4, half-maximal inhibitory concentration: > 50000 nM
Compound 4 was reported as a limit (the forecaster's own chance of this, stated with the estimate: 70%); the middle value is on the limit's open side.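

Placing 1,3-dicarboxypropyl on the amide-type nitrogen brings no numbered value back in this assay, and the step between compound 3 and compound 4 cannot be read. Two steps can be read: there is an at least 5.0-fold higher number from compound 2 to compound 4 (0.69 log units; beyond the scatter), and there is an at least 7.7-fold higher number from compound 1 to compound 4 (0.89 log units; beyond the scatter). So two different groups, one with two hydroxyls and one with two carboxylic acids, end at the same limit: the limit of > 50000 nM in this assay, at which 2 of the 4 values shown sit.

As far as these compounds go, how far past that limit compound 3 and compound 4 lie stays unknown, so the two groups cannot be ranked. From the compounds shown here alone, whether a single carboxylic acid, or an amine on a longer chain than the 2-aminoethyl of compound 1, would give a numbered value stays open.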